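A Benzyl Ketone Among Inactive Compounds

This account rests on a few compounds, and the source may have more. Where it says the series, first, only, none or still open, it means among the compounds named here.

In a functional assay on HeLa cells (Homo sapiens) for antiproliferative activity, read by sulforhodamine B assay (on this read-out lower numbers stand for stronger inhibition of growth and higher numbers for weaker inhibition of growth), three compounds have been measured. Compound 1 `CC(C)C[C@@H]1O[C@H](COCc2ccccc2)[C@@H](OCc2ccccc2)[C@H](OCc2ccccc2)[C@H]1O` gives > 50000 nM, which is a limit of the assay. Compound 2 `c1ccc(COC[C@H]2O[C@@H]3C[C@@H]3[C@@H](OCc3ccccc3)[C@@H]2OCc2ccccc2)cc1` gives > 50000 nM, again a limit. Compound 3 `CC[C@@H]1O[C@H](COCc2ccccc2)[C@@H](OCc2ccccc2)[C@H](OCc2ccccc2)C1=O` gives > 50000 nM, also a limit. Compound 3 therefore stands with the other two at the limit of > 50000 nM in this assay, at which 3 of the 3 values shown sit.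

Compound 4 `O=C1[C@H](Cc2ccccc2)O[C@H](COCc2ccccc2)[C@@H](OCc2ccccc2)[C@@H]1OCc1ccccc1` departs from compound 3 by one change, phenyl in place of methyl on a saturated chain carbon bound to a saturated ring carbon, which also reads as ethyl to benzyl. Among the compounds with values here, no measured pair differs in only one place, so the data offer no step to use as a guide. The expected at least 1.2-fold lower number from compound 3 to compound 4 (0.09 log units; that floor lies within the scatter) is small, at most a modest move toward stronger inhibition in this assay. That expectation rests on compound 3, whose > 50000 nM is a limit and shows no measurable activity to build on. A further limit would be the likeliest reading. Should a number appear for compound 4, the estimate is 40000 nM, with an expected range from 10000 nM to 50000 nM.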

Compound 4, concentration for 50% growth inhibition: > 50000 nM
Compound 4: no number, only a limit (the forecaster's own chance of this, stated with the estimate: 65%); at least 1.2-fold (0.09 log units) between middle value and limit.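

Compound 3 and compound 4 both end at a limit rather than a number, so no step can be read between them. The compounds shown leave open which change to the shared core, if any, would give a measurable inhibition of growth, since all of them stand at the same place: the limit of > 50000 nM in this assay, at which 4 of the 4 values shown sit.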